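The source may report more compounds than this note shows. Statements on the series, on what has been measured and on what is new or still open speak of the compounds shown alone.

Of the compounds shown here, three sharing one core have been measured in a functional assay on SW-620 cells (Homo sapiens) for inhibition, read by MTT assay, with a stated time of 72 h; a higher number here means a weaker inhibitor, a lower number a stronger inhibitor. Compound 1 `COc1cc(Oc2cccc(Nc3ccccc3)c2)cc(OC)c1CNCc1ccccc1` gives 7490 nM in this assay. Compound 2 `CNCc1c(OC)cc(Oc2cccc(Nc3ccccc3)c2)cc1OC`, in which hydrogen replaces phenyl on the saturated chain carbon bound to the amine nitrogen, gives 15000 nM in this assay, a change of a 2.0-fold higher number from compound 1 to compound 2 (0.30 log units; within the scatter). Compound 3 `COc1cc(Oc2cccc(Nc3ccccc3)c2)cc(OC)c1CNCc1ccc(Cl)cc1` carries chloro in place of hydrogen on an aromatic carbon and gives 6340 nM in this assay. The change from the parent is a 1.2-fold lower number from compound 1 to compound 3 (0.07 log units; within the scatter), and the change from the smaller amine is a 2.4-fold lower number from compound 2 to compound 3 (0.37 log units; beyond the scatter). Compound 3 thus has the lowest of the three numbers, although it sits within the scatter of compound 1 and is separated from compound 2 only by a modest margin.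

Compound 4 `COc1cc(Oc2cccc(Nc3ccccc3)c2)cc(OC)c1CNCc1ccc(O)cc1` has not been measured. It differs from compound 3 by hydroxy in place of chloro on an aromatic carbon, on an aromatic carbon of a six-membered aromatic ring of carbon only, para to a large group. The step that bears most directly on this change is a 1.2-fold lower number from compound 1 to compound 3 (0.07 log units; within the scatter), which shows that this position accepted chloro in place of hydrogen with no shift beyond the scatter. A hydroxy group at the same position is therefore expected to give only a small shift, with no firm direction, and the expected step is a 1.2-fold higher number from compound 3 to compound 4 (0.07 log units; within the scatter). For compound 4 the estimate in this assay is 7500 nM, with a range from 3000 nM to 18000 nM.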

Compound 4, half-maximal inhibitory concentration: 7940 nM
Estimate against measurement, compound 4: 1.1-fold (0.02 log units) below, within the range that was stated.
By their numbers in this assay, from the lowest: compounds 3, 1, 4 and 2 (each within the scatter of the next, the first and the last beyond it).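

In this assay, the change from chloro to hydroxy is a 1.3-fold higher number from compound 3 to compound 4 (0.10 log units; within the scatter) and the change from the unsubstituted ring is a 1.1-fold higher number from compound 1 to compound 4 (0.03 log units; within the scatter), so this position, para to a large group, now accepts a group counted as a hydrogen-bond donor and acceptor, as well as chloro, which is counted as neither, with no shift beyond the scatter. The step from the smaller amine is a 1.9-fold lower number from compound 2 to compound 4 (0.28 log units; within the scatter), which stays within the scatter even though the matching step to the 4-chlorophenyl compound, a 2.4-fold lower number from compound 2 to compound 3 (0.37 log units; beyond the scatter) in the same assay, lies just beyond it; since compound 3 and compound 4 are themselves within the scatter, this contrast does not separate the two groups. Nothing available explains why these two groups behave so alike.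

On these data alone, whether an amine or a carboxylic acid at this same place would move the number beyond the scatter remains open. Also open, as far as these compounds go, is what a longer chain linking the amine nitrogen to the aromatic ring would do, since every benzyl compound here has the same short link.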